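Nitro for acetamido at the limit of the assay

The compounds below may be only part of what the source reports. "The series", "measured", "known", "first", "only" and "open" are said of these compounds alone.

Compound 1 `O=C1NC(=O)N(/N=C/c2ccc(-c3ccc(Cl)cc3)o2)C1O` and compound 2 `CC(=O)Nc1ccc(-c2ccc(/C=N/N3C(=O)NC(=O)C3O)o2)cc1` share one core and differ in a single group. In a functional assay on the whole organism for activation, with Mus musculus as the target, with a stated time of 60 min (on this read-out higher numbers stand for an effect only at larger amounts of compound and lower numbers for an effect already at smaller amounts), compound 1 gives > 1000 mg/kg, which is a limit of the assay and not a number. Compound 2 gives > 1000 mg/kg, and this too is only a limit. Compound 2 therefore stands at the limit of > 1000 mg/kg in this assay, at which 2 of the 2 values shown sit, with no number of its own.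

Compound 3 `O=C1NC(=O)N(/N=C/c2ccc(-c3ccc([N+](=O)[O-])cc3)o2)C1O` keeps the core of compound 2 and exchanges one group: nitro in place of acetamido on an aromatic carbon. This puts nitro in place of acetamido on an aromatic carbon, para to a large group. Within the data shown here, the one measured step that bears on this change is a step that the two limits leave unreadable from compound 1 to compound 2, where acetamido took the place of chloro on an aromatic carbon. Its size cannot be read, so it offers neither a size nor a direction to carry over, and the expectation stays close to the limit in this assay. The estimated step is a number no higher from compound 2 to compound 3 (the limit leaves the size open), with no firm direction expected. For compound 3 the estimated value is 1000 mg/kg, with an expected range from 250 mg/kg to 2000 mg/kg.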

Compound 3, dose for half-maximal effect: > 1000 mg/kg
Compound 3: a limit, no number (the forecaster's own chance of this, stated with the estimate: 60%); the middle value sits exactly at the limit.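

No step among compound 1, compound 2 and compound 3 can be read in this assay, since each of them gives only a limit of the assay and not a number: the limit of > 1000 mg/kg in this assay, at which 3 of the 3 values shown sit.

The compounds shown leave open at what dose any of the three reaches a half-maximal effect, and whether chloro, acetamido and nitro differ at all.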